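Acetyl to dimethylamino: cell tolerance at the assay limit

The source may report more compounds than this note shows. Statements on the series, on what has been measured and on what is new or still open speak of the compounds shown alone.

Compound 1 `COc1cc(C)cc(-c2c(-c3ccnc(-c4ccc(C(C)=O)cc4)c3)cnn2CC#N)c1` is the starting point of this step, measured in a functional assay on SNB-75 cells (Homo sapiens) for inhibition, read by sulforhodamine B assay, with a stated time of 48 h; a higher number here means that more compound is tolerated, a lower number that less compound is tolerated. In this assay compound 1 gives > 100000 nM, which is a limit of the assay and not a number. Compound 2 `COc1cc(C)cc(-c2nn(CC#N)cc2-c2ccc(-c3cccc(C(C)=O)c3)nc2)c1` likewise returns > 100000 nM, again a limit. Compound 3 `Cc1cc(O)cc(-c2nn(CC#N)cc2-c2ccnc(-c3ccc(N(C)C)cc3)c2)c1`, which carries a dimethylamino group, also sits at the limit with > 100000 nM. Every value here is therefore (the limit of > 100000 nM in this assay, at which 3 of the 3 values shown sit). For the measured compounds named here, no step between measured compounds can be stated, and compound 1 stands nowhere except at that limit, alongside the other two.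

Compound 4 `COc1cc(C)cc(-c2c(-c3ccnc(-c4ccc(N(C)C)cc4)c3)cnn2CC#N)c1` is the member not yet measured. It differs from compound 1 by dimethylamino in place of acetyl on an aromatic carbon, in words: dimethylamino in place of acetyl on an aromatic carbon, or, read one bond further out, 4-acetylphenyl to 4-(dimethylamino)phenyl.

Going by the values given here, with three limits and no measured step, no direction for this change can be drawn from the data. Compound 3, already bearing the dimethylamino group, gives > 100000 nM in this assay, a limit. The step from compound 1 to compound 4 is therefore expected to be a step that the limit leaves unreadable from compound 1 to compound 4, none beyond the scatter. Compound 4 is estimated at 150000 nM, with a range from 50000 nM to 500000 nM, and most likely again reported only as a limit.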

Compound 4, concentration lethal to 50% of the cells: > 100000 nM
Compound 4 ended at the assay's limit; the forecaster's own chance of this, stated with the estimate: 85%; the middle value does not contradict the limit.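

In this assay compound 4 gives > 100000 nM, a limit of the assay and not a number. No step can be read between compound 1 and compound 4: the limit of > 100000 nM in this assay, at which 4 of the 4 values shown sit.

The compounds shown leave open whether dimethylamino in place of acetyl changes the read-out in this assay at all, as none of them gives a value short of the limit.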